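A Methoxy Step Repeated on a Second Core

This account rests on a few compounds, and the source may have more. Where it says the series, first, only, none or still open, it means among the compounds named here.

Of the compounds shown here, three have been measured in a functional assay on MDA-MB-231 cells (Homo sapiens) for antiproliferative activity, read by MTT assay, with a stated time of 24 h; a higher number here means a weaker inhibitor, a lower number a stronger inhibitor. Compound 1 `COc1ccc(/C=C/C(=O)c2cc(-c3cc(OC)c(OC)c(OC)c3)n3nc(-c4ccccc4)cc3n2)cc1OC` gives 14200 nM in this assay. Compound 3 `COc1ccc(/C=C/C(=O)c2cc(-c3cc(OC)c(OC)c(OC)c3)n3nc(-c4ccccc4)cc3n2)cc1` gives 16500 nM. Compound 2 `COc1ccc(-c2cc(/C=C/C(=O)c3ccccc3)nc3cc(-c4ccccc4)nn23)cc1`, which is built on a different core, gives 9900 nM; how the core of compound 2 differs from that of compound 3 is not broken down here, so the two are described only by their values.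

Compounds 3 and 1 differ in one place, (methoxy in place of hydrogen on an aromatic carbon), and the measured step is a 1.2-fold lower number from compound 3 to compound 1 (0.07 log units; within the scatter). The same change is made again on the second core, from compound 2 to the unmeasured compound 4 `COc1ccc(-c2cc(/C=C/C(=O)c3ccccc3)nc3cc(-c4ccccc4)nn23)cc1OC`: the difference is methoxy in place of hydrogen on an aromatic carbon, and the surroundings of the place are described in the same words as for the pair of compounds 3 and 1, so it is the same change, occurring twice among the compounds shown.

Among the measured compounds shown here, since only one measured instance of the change exists, the expectation for compound 4 rests on that single pair. The expected step in this assay is a 1.2-fold lower number from compound 2 to compound 4 (0.07 log units; within the scatter), because compound 3 and compound 1 show a 1.2-fold lower number from compound 3 to compound 1 (0.07 log units; within the scatter). Compound 4 is therefore estimated to give 8500 nM in this assay. The estimate for compound 4 is expected to lie between 4000 nM and 18000 nM, given the scatter such measurements carry.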

Compound 4, half-maximal inhibitory concentration: 11800 nM
For compound 4 the middle estimate is 1.4-fold (0.14 log units) below the measured one, and the stated range covers the measured number.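

Carried to the second core, the change from 4-methoxyphenyl to 3,4-dimethoxyphenyl gives, in this assay, a 1.2-fold higher number from compound 2 to compound 4 (0.08 log units; within the scatter), so on this core too the added methoxy leaves the number within the scatter of repeated measurements. Set beside the earlier pair, the step on the second core does not stand apart from the step on the first, and the change reads the same on both cores within what the measurements can resolve: the same change on two cores in this assay, a 1.2-fold lower number (0.07 log units; within the scatter) from compound 3 to compound 1 and a 1.2-fold higher number (0.08 log units; within the scatter) from compound 2 to compound 4, 1.4-fold (0.14 log units) apart, within the scatter of two such steps What this does not show is a direction for the change, as neither step is large enough for its printed sign to carry weight, and two pairs say nothing about how the change would read on any core beyond these two.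

The compounds shown leave open whether any other group at this place on the aromatic ring, such as an amine, a carboxylic acid or a longer chain like butoxy, would produce a step beyond the scatter on either core. They also leave open how much the cores themselves contribute, since no pair shown isolates a difference between them in a single place.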